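Compound 4 in the L02 Cytotoxicity Series

The source may report more compounds than this note shows. Statements on the series, on what has been measured and on what is new or still open speak of the compounds shown alone.

Compound 1 `CN1C/C(=C\c2ccc(C(C)(C)C)cc2)C(=O)/C(=C/c2ccccc2F)C1`: 25800 nM
Compound 2 `COc1cc(/C=C2\CN(C)C/C(=C\c3cc(OC)c(OC)c(OC)c3)C2=O)cc(OC)c1`: 14600 nM
Compound 3 `CN1C/C(=C\c2ccc(F)cc2)C(=O)/C(=C/c2cccc([N+](=O)[O-])c2)C1`: 17600 nM

These three compounds were tested in an ADME assay on L02 cells (Homo sapiens) for cytotoxicity, read by MTT assay, with a stated time of 24 h; a higher number here means a weaker inhibitor, a lower number a stronger inhibitor. In this assay compound 3 gives 17600 nM, a number that lies within the scatter of both compound 2 and compound 1. The three measurements therefore do not set compound 3 apart from either of the others.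

Compound 4 `CN1C/C(=C\c2cccc([N+](=O)[O-])c2)C(=O)/C(=C/c2ccc(Cl)cc2Cl)C1` has not yet been measured. It differs from compound 3 in one place: 2,4-dichlorophenyl in place of 4-fluorophenyl on a double-bonded chain carbon bound to a double-bonded ring carbon. In words, it has 2,4-dichlorophenyl in place of 4-fluorophenyl on a double-bonded chain carbon bound to a double-bonded ring carbon.

For the measured compounds named here, no two measured compounds differ in only one place, so the data show no direct size for a change of this kind. Going by the values given here, the compounds measured so far all stay close together, even though they differ in several places at once. On that thin basis, no step beyond the scatter is expected in this assay, and neither direction is favoured. The expected change is small, an estimated 1.1-fold lower number from compound 3 to compound 4 (0.04 log units; within the scatter). For compound 4 the estimated value is 16000 nM, with an expected range from 8000 nM to 32000 nM.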

Compound 4, half-maximal inhibitory concentration: 14000 nM
The estimate for compound 4 lay 1.1-fold (0.06 log units) above the measured number; the measured number falls inside the stated range.
By their numbers in this assay, from the lowest: compounds 4, 2, 3 and 1 (each within the scatter of the next).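

In this assay, for the compounds shown here, the exchange of 4-fluorophenyl for 2,4-dichlorophenyl on a double-bonded chain carbon bound to a double-bonded ring carbon gives the first change at a single place, a 1.3-fold lower number from compound 3 to compound 4 (0.10 log units; within the scatter), and this step stays within the scatter. Going by these compounds alone, at this position, then, the group with 8 heavy atoms and two chlorine atoms reads no differently from the group with 7 heavy atoms and one fluorine atom, which the earlier compounds, all differing in several places at once, could not show. No measurement at hand speaks to why the step is this small.

The compounds shown leave open whether a group of a different kind at this position, such as an amine, a carboxylic acid or a longer chain, would move the number beyond the scatter. Within the data shown here, they also leave open whether the same exchange would give a step of similar size if the rest of the shared core carried other groups, as this single pair is the only direct comparison available.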